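The source may hold more compounds than are shown below. What is called first, only, known or untested is meant among the compounds shown, and "the series" means these compounds.

Among the compounds with values here, compound 2 `COc1cc2c(Oc3ccc(NC(=O)c4nn(-c5ccccc5C)c(=O)cc4C)cc3F)ccnc2cc1OCCCN1CCC(C)CC1` stands at 1290 nM in a functional assay on MKN-45 cells (Homo sapiens) for inhibition, read by MTT assay, with a stated time of 72 h (a higher number here means a weaker inhibitor, a lower number a stronger inhibitor), with compound 1 `COc1cc2c(Oc3ccc(NC(=O)c4nn(-c5ccccc5C)c(=O)cc4C)cc3F)ccnc2cc1OCCCN1CCCCC1` at 1310 nM within the scatter of it, the only other number measured; the single step recorded is a 1.0-fold lower number from compound 1 to compound 2 (0.01 log units; within the scatter). Compound 3 `COc1cc2c(Oc3ccc(NC(=O)c4nn(-c5ccc(Cl)cc5)c(=O)cc4C)cc3F)ccnc2cc1OCCCN1CCC(C)CC1` differs from compound 2 by 4-chlorophenyl in place of 2-methylphenyl on an aromatic nitrogen. Within the data shown here, that step concerns the saturated ring, not the aromatic nitrogen, so no measured step bears on this change and nothing points in either direction. Compound 3 is therefore expected to show a step of a 1.1-fold lower number from compound 2 to compound 3 (0.03 log units; within the scatter), within the scatter. Compound 3 is estimated at 1200 nM, between 350 nM and 4500 nM.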

Compound 3, half-maximal inhibitory concentration: 150 nM
Compound 3: middle estimate off by 8.0-fold (0.90 log units), on the high side; the whole stated range lies above it.
By their numbers in this assay, from the lowest: compound 3; then compounds 2 and 1 (each within the scatter of the next).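

In this assay, the group on the aromatic nitrogen proves to be a position that moves the number, unlike the methyl on the saturated ring: 4-chlorophenyl in place of 2-methylphenyl gives an 8.6-fold lower number from compound 2 to compound 3 (0.93 log units; beyond the scatter). The two groups have the same number of heavy atoms, yet they do not behave alike here. Nothing measured on these compounds accounts for the step. This single change both removes the 2-methyl and adds the 4-chloro, so the compounds shown cannot separate the two. Plain phenyl, 2-chlorophenyl or 4-methylphenyl on that nitrogen would remain to be compared.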